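A few compounds are considered here, and "the series" means these few. Any claim that something is new, unique, unknown or untested is made for them only; others in the source may bear on it.

Measured so far:
- compound 1, `COc1ccc(Cc2cnc(CCc3ccc(-c4ccccc4C(=O)O)cc3)[nH]2)cc1` — in an in vitro functional assay on cells for agonist activity at Bombesin receptor subtype-3 (Mus musculus), read by luminescence and calcium flux (on this read-out lower numbers stand for an effect already at smaller amounts and higher numbers for an effect only at larger amounts of compound), compound 1 gives 513 nM
- compound 2, `CCC(C)(CC)Cc1cnc(CCc2ccc(-c3ccccc3C(=O)O)cc2)[nH]1` — in this assay compound 2 gives 30 nM

Compound 2 stands with the lowest of the two numbers; its nearest neighbour is compound 1, and the step between them, a 17-fold lower number from compound 1 to compound 2 (1.23 log units; beyond the scatter), is large and beyond the scatter. That single step is the only one that bears on the next compound, and it shows that replacing an aromatic group on the saturated chain carbon bound to an aromatic carbon with the 1-ethyl-1-methylpropyl group lowered the number sharply.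

Compound 3, `O=C(O)c1ccccc1-c1ccc(CCc2ncc(Cc3cccc(F)c3F)[nH]2)cc1`, is not yet measured. It differs from compound 2 by 2,3-difluorophenyl in place of 1-ethyl-1-methylpropyl on a saturated chain carbon bound to an aromatic carbon. This change reverses the kind of substitution seen in the measured step: an aromatic ring returns to the place where the branched alkyl sat in compound 2. On that basis the number for compound 3 is expected to move back toward the region of compound 1, a step expected to read a 10-fold higher number from compound 2 to compound 3 (1.00 log units; beyond the scatter), upward and beyond the scatter, although the two fluorines leave the exact size uncertain. The estimate for compound 3 in this assay is 300 nM, within a range of 90 nM to 1000 nM.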

Compound 3, half-maximal effective concentration: 8 nM
Compound 3: the middle estimate sits 38-fold (1.57 log units) above what was measured, outside the stated range (below it).
By their numbers in this assay, from the lowest: compound 3; then compound 2; then compound 1.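

Among the compounds shown here, the saturated chain carbon bound to an aromatic carbon can carry an aromatic ring and still give a low number: in this assay, 2,3-difluorophenyl in place of 1-ethyl-1-methylpropyl gives a 3.8-fold lower number from compound 2 to compound 3 (0.57 log units; beyond the scatter), so the branched alkyl group is not the only kind of group that does well here. The presence of a ring does not settle the number, for 2,3-difluorophenyl in place of 4-methoxyphenyl, with a six-membered aromatic ring on both sides of the change, gives a 64-fold lower number from compound 1 to compound 3 (1.81 log units; beyond the scatter). What the ring carries therefore matters at this place, and among the three groups compared, 2,3-difluorophenyl gives the lowest number, with both of its steps beyond the scatter.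

Nothing at hand says why this ring gives a lower number than the other two groups. The change from 4-methoxyphenyl to 2,3-difluorophenyl removes one substituent and brings in two others at once, so the compounds shown do not separate the contribution of each fluorine from that of the lost methoxy group, a question that unsubstituted phenyl, 2-fluorophenyl or 3-fluorophenyl at this place would bear on.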